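Adding a second ester to compound 2

The source may report more compounds than this note shows. Statements on the series, on what has been measured and on what is new or still open speak of the compounds shown alone.

Working notes on a series sharing one core, tested in a functional assay on CNE cells (Homo sapiens) for cytotoxicity, read by MTT assay, with a stated time of 48 h; a lower number here means a stronger inhibitor, a higher number a weaker inhibitor. Compound 1 (`C/C=C(\C)C(=O)O[C@H]1C[C@@](C)(O)[C@]23C=C[C@](C)([C@@H]2[C@H]2OC(=O)[C@@H](C)[C@@H]21)[C@]1(C3)C(=O)O[C@@H]2[C@H]3C(C)=CC[C@H]3[C@](C)(O)C[C@H](O)[C@H]21`) gives > 10000 nM, which is a limit of the assay and not a number. Compound 2 (`C=C1C(=O)O[C@H]2[C@H]1[C@@H](OC(=O)/C(C)=C/C)C[C@@](C)(O)[C@]13C=C[C@](C)([C@H]21)[C@]1(C3)C(=O)O[C@@H]2[C@H]3C(C)=CC[C@H]3[C@](C)(O)C[C@H](O)[C@H]21`) gives > 10000 nM, which is also a limit. Compound 2 therefore has no numerical standing, and no order can be drawn from the data; it sits at the limit of > 10000 nM in this assay, at which 2 of the 2 values shown sit.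

Compound 3 (`C=C1C(=O)O[C@H]2[C@H]1[C@@H](OC(=O)/C(C)=C/C)C[C@@](C)(O)[C@]13C=C[C@](C)([C@H]21)[C@]1(C3)C(=O)O[C@@H]2[C@H]3C(C)=CC[C@H]3[C@](C)(O)C[C@H](OC(=O)/C(C)=C/C)[C@H]21`) differs from compound 2 by one change: (1-methylprop-1-en-1-yl)carbonyl in place of hydrogen on an oxygen on a saturated carbon. In words, the hydroxy becomes ((1-methylprop-1-en-1-yl)carbonyl)oxy. Going by the values given here, no measured step speaks to this change. In this assay, the expected change is none beyond the scatter, and the estimated step is a step that the limit leaves unreadable from compound 2 to compound 3. For compound 3 the expected value is 12000 nM, with an estimated range of 5000 nM to 30000 nM.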

Compound 3, half-maximal inhibitory concentration: 4600 nM
The estimate for compound 3 lay 2.6-fold (0.42 log units) above the measured number, outside the stated range (below it).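

In this assay, going by these compounds alone, compound 3 gives 4600 nM, the first value that is a number and not a limit, so this oxygen on a saturated carbon is a position where a change can be read. Going from hydroxy to ((1-methylprop-1-en-1-yl)carbonyl)oxy there gives an at least 2.1-fold lower number from compound 2 to compound 3 (0.33 log units; beyond the scatter). That size is only a lower bound, because compound 2 stands at a limit: the limit of > 10000 nM in this assay, at which 2 of the 3 values shown sit.

On these data alone, what stays open is whether the step belongs to this particular ester or to any acyl group on this oxygen. As far as these compounds go, an acetyl ester, a longer saturated chain ester or an ether at the same oxygen would separate these readings, and the full size of the step remains unknown.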